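A few compounds are considered here, and "the series" means these few. Any claim that something is new, unique, unknown or untested is made for them only; others in the source may bear on it.

Compound 2 `CCOC(=O)CCCCCOc1cccc(CN(C(=O)c2ccc(-c3cnc(OC)nc3OC)cc2)C(C)C)c1` is an amide carrying a 2,4-dimethoxypyrimidin-5-yl group. In an ADME assay on Raji cells (Homo sapiens) for cytotoxicity, read by CellTiter-Glo and resazurin assay, with a stated time of 72 h (on this read-out lower numbers stand for an effect already at smaller amounts and higher numbers for an effect only at larger amounts of compound), compound 2 gives > 26000 nM, which is a limit of the assay rather than a number. Compound 1 `COc1cc(F)cc(-c2ccc(C(=O)N(Cc3cccc(OCCCCCC(=O)O)c3)C(C)C)cc2)c1` is its relative with a free carboxylic acid. In this assay compound 1 gives > 26000 nM, again a limit. For the measured compounds named here, both values rest at the limit of > 26000 nM in this assay, at which 2 of the 2 values shown sit, so no measured step between them can be stated.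

Compound 3 `CCOC(=O)CCCCCOc1cccc(CN(C(=O)c2ccc(-c3cccc(OC)c3)cc2)C(C)C)c1` is the next compound, and it differs from compound 2 as follows: 3-methoxyphenyl in place of 2,4-dimethoxypyrimidin-5-yl on an aromatic carbon.

Going by the values given here, with no measured step to lean on, no change beyond the scatter is expected in this assay. Compound 3 is therefore estimated at 30000 nM, in the range 15000 nM to 80000 nM, with the expected step that the limit leaves unreadable from compound 2 to compound 3.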

Compound 3, half-maximal effective concentration: > 21000 nM
Compound 3: no number, only a limit; the forecaster's own chance of this, stated with the estimate: 70%; the middle value is on the limit's open side.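

For the compounds shown here, compound 2 and compound 3 each give only a limit of the assay and not a number, so no step between them can be read. The compounds shown leave open what concentration of any of them would produce an effect in this assay.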